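The source may hold more compounds than are shown below. What is called first, only, known or untested is meant among the compounds shown, and "the series" means these compounds.

Measured so far in a functional assay on HeLa cells (Homo sapiens) for cytotoxicity, read by MTT assay, with a stated time of 48 h; on this read-out higher numbers stand for weaker inhibition and lower numbers for stronger inhibition:

Compound 1 `O=[N+]([O-])c1cc(-c2nc3ccc([N+](=O)[O-])cc3[nH]2)cc(-c2nc3ccc([N+](=O)[O-])cc3[nH]2)c1` gives 1200 nM.
Compound 2 `Clc1ccc2nc(-c3cccc(-c4nc5ccc(Cl)cc5[nH]4)c3)[nH]c2c1` gives 10700 nM.
Compound 3 `FC(F)(F)c1ccc2nc(-c3cccc(-c4nc5ccc(C(F)(F)F)cc5[nH]4)c3)[nH]c2c1` gives 8000 nM.

Among these three numbers, compound 3 holds the second highest. Its value and that of compound 2 lie within the scatter of each other, so on this read-out the two cannot be told apart. Compound 1 sits well below compound 3, and that gap is beyond the scatter, so compound 1 is the one that clearly inhibits more strongly.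

Compound 4 `COc1cc(-c2nc3ccc(C(F)(F)F)cc3[nH]2)cc(-c2nc3ccc(C(F)(F)F)cc3[nH]2)c1` has not yet been tested in this assay. It differs from compound 3 in a single place: methoxy in place of hydrogen on an aromatic carbon. Among the compounds with values here, no pair of measured compounds shows this kind of change, so there is no measured step on which to base a direction. The change adds only a methoxy while the shared core and both trifluoromethyl groups remain as in compound 3. The expected step is a 1.2-fold lower number from compound 3 to compound 4 (0.09 log units; within the scatter), which amounts to no change beyond the scatter in either direction. Compound 4 is therefore expected to give about 6500 nM, within a range from 2000 nM to 20000 nM.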

Compound 4, half-maximal inhibitory concentration: 8400 nM
Compound 4: middle estimate off by 1.3-fold (0.11 log units), on the low side; the range from low to high includes it.
By their numbers in this assay, from the lowest: compound 1; then compounds 3, 4 and 2 (each within the scatter of the next).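

In this assay the piece now has its first step between two compounds that differ in one place: a 1.1-fold higher number from compound 3 to compound 4 (0.02 log units; within the scatter) with methoxy in place of hydrogen on an aromatic carbon. The earlier compounds shown here could not show this, since no two of them formed such a pair. The step shows that in the setting of compound 3, with both trifluoromethyl groups kept, this carbon of the six-membered aromatic ring can carry methoxy with no difference that can be told from the scatter, although nothing available here explains this result.

Going by these compounds, whether this holds for other groups on the same carbon, such as an amine, a carboxylic acid or a longer chain, remains open, as one step with one group says little about the others. Compound 4 and compound 1 differ in more than one place, so nothing shown ties the value of compound 1 at 1200 nM to any one of its groups.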